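Fluoro in Place of Chloro on a Weak Inhibitor

The source may hold more compounds than are shown below. What is called first, only, known or untested is meant among the compounds shown, and "the series" means these compounds.

In a functional assay on HEp-2 cells (Homo sapiens) for inhibition (a lower number here means a stronger inhibitor, a higher number a weaker inhibitor), compound 1 (`O=C1O/C(=C\Cn2ccc(=O)[nH]c2=O)C(OCc2ccccc2)=C1OCc1ccccc1`) gives 40000 nM, and compound 2 (`O=C1O/C(=C\Cn2cc(Cl)c(=O)[nH]c2=O)C(OCc2ccccc2)=C1OCc1ccccc1`) gives 20000 nM. These two values lie within the scatter of each other, so compound 2 does not stand apart from compound 1 on the numbers available.

Compound 3 (`O=C1O/C(=C\Cn2cc(F)c(=O)[nH]c2=O)C(OCc2ccccc2)=C1OCc1ccccc1`) has not yet been measured. It differs from compound 2 by a single substitution: fluoro in place of chloro on an aromatic carbon. In words, this is fluoro in place of chloro on an aromatic carbon.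

Within the data shown here, only one measured step bears on this change: a 2.0-fold lower number from compound 1 to compound 2 (0.30 log units; within the scatter), with chloro in place of hydrogen on an aromatic carbon. That step lies within the scatter. Among the measured compounds shown here, no measured compound carries fluoro, so the data offer no direct reading of this group, and the range must stay wide. With only so small a step on record, no shift beyond the scatter is expected in this assay. The expected step is no change at the digits printed from compound 2 to compound 3 (within the scatter). For compound 3 the estimated value is 20000 nM, with an expected range from 5000 nM to 45000 nM.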

Compound 3, half-maximal inhibitory concentration: 20000 nM
The estimate for compound 3 equals the measured number at the digits printed; the measured number falls inside the stated range.
By their numbers in this assay, from the lowest: compounds 2, 3 and 1 (each within the scatter of the next).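

In this assay, replacing chloro with fluoro on this aromatic carbon gives no change at the digits printed from compound 2 to compound 3 (within the scatter), so the two halogens cannot be told apart at this position. Compound 3 also adds a second comparison with the hydrogen parent: fluoro in place of hydrogen gives a 2.0-fold lower number from compound 1 to compound 3 (0.30 log units; within the scatter), which matches the earlier chloro step, a 2.0-fold lower number from compound 1 to compound 2 (0.30 log units; within the scatter), and means that neither halogen stands clear of hydrogen on these numbers. No measurement among these results offers an explanation for this flat reading.

From the compounds shown here alone, the three compounds span only hydrogen, chloro and fluoro at this carbon, so it remains open whether a group of another kind there, such as an amine, a methyl or a carboxylic acid, would produce a step beyond the scatter. All three also share the rest of the structure, including both benzyloxy groups, which leaves open whether replacing those groups with hydroxyl, or changing the chain that links the two parts of the core, would matter more in this assay than anything yet seen at this position.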